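Phenyl for thiophen-2-yl: what to expect of compound 4

This account rests on a few compounds, and the source may have more. Where it says the series, first, only, none or still open, it means among the compounds named here.

Compound 1 `Oc1cccc(-c2cc(-c3ccc(Cl)cc3)nc(-c3cccs3)c2)c1` gives 11600 nM in a functional assay on DU-145 cells (Homo sapiens) for cytotoxicity, read by CCK-8 assay and cell counting, with a stated time of 2 days (on this read-out higher numbers stand for weaker inhibition and lower numbers for stronger inhibition), the highest of the three numbers shown here, with compound 2 inside the usual scatter of it and compound 3 clearly lower. Compound 2 `Oc1ccc(-c2cc(-c3ccc(Cl)cc3)nc(-c3cccs3)c2)cc1` gives 7660 nM, and compound 3 `Oc1cccc(-c2cc(-c3cccs3)nc(-c3ccccc3Cl)c2)c1` gives 1700 nM. The step of a 1.5-fold lower number from compound 1 to compound 2 (0.18 log units; within the scatter) altered only the hydroxyphenyl group, whereas a 6.8-fold lower number from compound 1 to compound 3 (0.83 log units; beyond the scatter) altered only the chlorophenyl group. Compound 4 `Oc1cccc(-c2cc(-c3ccccc3)nc(-c3ccc(Cl)cc3)c2)c1` differs from compound 1 by phenyl in place of thiophen-2-yl on an aromatic carbon. For the measured compounds named here, neither measured step touches the thiophen-2-yl group, so no measured step bears directly on this change. The expected step is therefore none beyond the scatter, a 1.2-fold lower number from compound 1 to compound 4 (0.06 log units; within the scatter). Compound 4 is estimated at 10000 nM, within a range of 3000 nM to 35000 nM.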

Compound 4, half-maximal inhibitory concentration: 11200 nM
Estimate against measurement, compound 4: 1.1-fold (0.05 log units) below; measured number inside the range.
By their numbers in this assay, from the lowest: compound 3; then compounds 2, 4 and 1 (each within the scatter of the next).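

Phenyl in place of thiophen-2-yl next to the ring nitrogen gives a 1.0-fold lower number from compound 1 to compound 4 (0.02 log units; within the scatter) and so offers the first reading at this position, which the earlier steps left untouched. With the 4-chlorophenyl and 3-hydroxyphenyl groups in place, this read-out does not separate the five-membered sulfur-containing ring from the six-membered carbon ring. Nothing shown here explains why the two rings read alike.

Going by these compounds, whether the same swap reads alike in compound 3, which carries 2-chlorophenyl, remains open. So does whether this position tolerates a non-aromatic group such as a morpholine or a longer alkyl chain.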